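Adding a Methyl Beside the Hydroxyl of the Side Chain

This account rests on a few compounds, and the source may have more. Where it says the series, first, only, none or still open, it means among the compounds named here.

Three compounds share one core and differ only in the side chain attached to an amide. Compound 2 `O=C(CN(c1nc(Cl)nc2c1ncn2C1CCCCO1)C1CC1)NCC(=O)OCc1ccccc1`, compound 1 `C[C@H](NC(=O)CN(c1nc(Cl)nc2c1ncn2C1CCCCO1)C1CC1)C(=O)OCc1ccccc1` and compound 3 `O=C(CN(c1nc(Cl)nc2c1ncn2C1CCCCO1)C1CC1)N[C@@H](CO)C(=O)OCc1ccccc1` were each tested in a functional assay on the whole organism with Mus musculus as the target, with a stated time of 90 min, at a dose of 25 umol/kg by the oral route; on this read-out lower numbers stand for a weaker effect and higher numbers for a stronger effect at the one dose given. Compound 2 gives 25.9%, compound 1 gives 32.1% and compound 3 gives 32.2%. The change from compound 2 to compound 1 is methyl in place of hydrogen on a saturated chain carbon bound to an amide-type nitrogen and a carbonyl carbon, and it brought a number 6.2 percentage points higher from compound 2 to compound 1 (within the scatter). From compound 2 to compound 3 the read-out moved by a number 6.3 percentage points higher from compound 2 to compound 3 (within the scatter), and from compound 1 to compound 3 by a number 0.1 percentage points higher from compound 1 to compound 3 (within the scatter), so all three numbers sit close together.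

Compound 4 `C[C@@H](O)[C@H](NC(=O)CN(c1nc(Cl)nc2c1ncn2C1CCCCO1)C1CC1)C(=O)OCc1ccccc1` has not yet been tested in this assay. It differs from compound 3 by methyl in place of hydrogen on a saturated chain carbon bound to an oxygen on a saturated carbon and a saturated chain carbon. For the measured compounds named here, this is the same kind of change as the one from compound 2 to compound 1, but not the same change: there the methyl entered on a saturated chain carbon bound to an amide-type nitrogen and a carbonyl carbon, here it enters on a saturated chain carbon bound to an oxygen on a saturated carbon and a saturated chain carbon. The cores on which the two changes are made differ by hydroxymethyl in place of hydrogen on a saturated chain carbon bound to an amide-type nitrogen and a carbonyl carbon. Since the earlier methyl gave a number 6.2 percentage points higher from compound 2 to compound 1 (within the scatter), the step expected from compound 3 to compound 4 is a number 2.8 percentage points higher from compound 3 to compound 4 (within the scatter), again inside the usual scatter. Compound 4 is therefore estimated at 35%, with an expected range from 22% to 48%.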

Compound 4, a percentage reported as activity, at one dose (the size of the read-out at that dose, not a potency): 23.4%
Compound 4: the middle estimate sits 11.6 percentage points above what was measured; measured number inside the range.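

In this assay, a methyl added in this series does not bring the same step on both cores: the same change on two cores in this assay, a number 6.2 percentage points higher (within the scatter) from compound 2 to compound 1 and a number 8.8 percentage points lower (within the scatter) from compound 3 to compound 4, 15 percentage points apart, beyond the scatter of two such steps. Taken on its own, the new step is a number 8.8 percentage points lower from compound 3 to compound 4 (within the scatter) and the steps from the other two compounds are a number 2.5 percentage points lower from compound 2 to compound 4 (within the scatter) and a number 8.7 percentage points lower from compound 1 to compound 4 (within the scatter), so none of these steps separates compound 4 from compound 1, compound 2 or compound 3, and only the gap between the two methyl steps goes beyond the scatter. This shows that the step seen for the first methyl cannot simply be carried over to a methyl on the hydroxymethyl group, but it does not show why, since the two methyls sit on different carbons and on different cores, and a single pair of steps gives no rule for other cores in the series.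

The compounds shown leave open whether the gap depends on the methyl itself or on the hydroxy group kept in 1-hydroxyethyl. An amine or a carboxylic acid in place of that hydroxy group, or a longer chain in place of its methyl, would be needed to test how far this result extends.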